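Sulfonate esters on a shared core: iodo to methoxy

The source may report more compounds than this note shows. Statements on the series, on what has been measured and on what is new or still open speak of the compounds shown alone.

Compound 1 `CN1CCN(c2ccc(S(=O)(=O)Oc3cccc(Cl)c3)cc2)C1=O`: 2100 nM
Compound 2 `CN1CCN(c2ccc(S(=O)(=O)Oc3cccc(I)c3)cc2)C1=O`: 590 nM

In a functional assay on HT-29 cells (Homo sapiens) for antiproliferative activity, read by sulforhodamine B assay, with a stated time of 48 h (a lower number here means a stronger inhibitor, a higher number a weaker inhibitor), compound 2 gives the lowest of the two numbers recorded so far, with compound 1 as its nearest neighbour at a higher number. Among the compounds with values here, the one measured step, a 3.6-fold lower number from compound 1 to compound 2 (0.55 log units; beyond the scatter), concerns an exchange of one halogen for another on the aromatic ring attached through the oxygen. Compound 3 `COc1ccc(OS(=O)(=O)c2ccc(N3CCN(C)C3=O)cc2)cc1` changes that same ring more deeply: 4-methoxyphenyl in place of 3-iodophenyl on an oxygen. Within the data shown here, no measured step covers a halogen giving way to a methoxy group, so the expectation rests only on the fact that the ring carrying the iodine is the part being changed and that a step there already moved this assay beyond the scatter. Compound 3 is therefore expected to give a weaker result than compound 2, estimated at 3000 nM with a range from 800 nM to 12000 nM, a step of a 5.1-fold higher number from compound 2 to compound 3 (0.71 log units; beyond the scatter).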

Compound 3, half-maximal inhibitory concentration: > 100000 nM
Compound 3 gave a limit, no number (the forecaster's own chance of this, stated with the estimate: 10%); at least 33-fold (1.52 log units) between middle value and limit.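

In this assay compound 3 stands at a limit of the assay and not at a number: the limit of > 100000 nM in this assay, at which 1 of the 3 values shown sits. On the oxygen whose other neighbour is the sulfonyl sulfur, 4-methoxyphenyl in place of 3-iodophenyl gives an at least 160-fold higher number from compound 2 to compound 3 (2.22 log units; beyond the scatter), and in place of 3-chlorophenyl it gives an at least 47-fold higher number from compound 1 to compound 3 (1.67 log units; beyond the scatter). Both steps are large, whereas the exchange of one halogen for another gave only a 3.6-fold lower number from compound 1 to compound 2 (0.55 log units; beyond the scatter), so a change to this ring can do far more than shift the result modestly.

The compounds shown leave open whether the loss goes with the methoxy group itself or with its place on the ring, as 4-methoxyphenyl differs from 3-iodophenyl in both. Going by these compounds, how an amine or a carboxylic acid on this ring would read in this assay also remains open.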